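The source may report more compounds than this note shows. Statements on the series, on what has been measured and on what is new or still open speak of the compounds shown alone.

Compound 3, whose structure is `CCn1c(C(=O)On2nnc3ccccc32)ccc1C(CC)(CC)c1ccc(C#CC(O)(CC)CC)c(C)c1`, belongs to a small set of three measured compounds built on one shared core. In an assay on cells for agonist activity at vitamin D3 receptor (Homo sapiens), read by microscopy (a higher number here means that more compound is needed for the effect, a lower number that less compound is needed), compound 3 reaches only the limit of the assay, > 50 nM, so no number is known for it. Compound 2, with structure `CCn1c(C(=O)NCc2ccc(OC)cc2)ccc1C(CC)(CC)c1ccc(C#CC(O)(CC)CC)c(C)c1`, likewise reaches only a limit in this assay, > 50 nM. Compound 1, with structure `CCN(CC)CCNC(=O)c1ccc(C(CC)(CC)c2ccc(OCC(O)C(C)(C)C)c(C)c2)n1CC`, differs from both in more than one place and gives 6.54 nM in this assay.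

Among the measured compounds shown here, the only measured step that touches the carbonyl carbon, a step that the two limits leave unreadable from compound 2 to compound 3, cannot be read in size, because both of its values sit at the limit of > 50 nM in this assay, at which 2 of the 3 values shown sit. The change to compound 4, with structure `CCn1c(C(=O)NCCCO)ccc1C(CC)(CC)c1ccc(C#CC(O)(CC)CC)c(C)c1`, is a group of 5 heavy atoms (3 carbon, 1 nitrogen, 1 oxygen; no ring) in place of a group of 10 heavy atoms (6 carbon, 3 nitrogen, 1 oxygen; one five-membered aromatic ring with 3 hetero atoms, one six-membered aromatic ring of carbon only), on a carbonyl carbon: the (3-hydroxypropyl)amino group enters where the larger two-ring group left. For the measured compounds named here, no measured step shows what such a group does here, so the expected step of an at least 1.6-fold lower number from compound 3 to compound 4 (0.22 log units; that floor lies within the scatter) rests on the values alone, not on a direction read from them. Compound 4 is therefore estimated at 30 nM, within a wide range from 5 nM to 200 nM.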

Compound 4, half-maximal effective concentration: 137 nM
The estimate for compound 4 lay 4.6-fold (0.66 log units) below the measured number; the range from low to high includes it.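

Neither new comparison, compound 4 against compound 3 or compound 4 against compound 2, can be sized in this assay because compound 2 and compound 3 each give only a limit of the assay: the limit of > 50 nM in this assay, at which 2 of the 4 values shown sit.

Going by these compounds, what the (3-hydroxypropyl)amino group on the carbonyl carbon does to the number, compared with the groups of compound 2 and compound 3, stays open.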